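The source may hold more compounds than are shown below. What is called first, only, known or untested is meant among the compounds shown, and "the series" means these compounds.

Compound 1 `CC(C)[C@H](NC(=O)COc1cccc2ccccc12)C(=O)N[C@@H](CC(=O)O)C(=O)COc1ccc(-c2ccccc2)cc1` gives 87900 nM in a functional assay on Jurkat cells (Homo sapiens); on this read-out higher numbers stand for weaker inhibition and lower numbers for stronger inhibition. Compound 2 `CC(C)[C@H](NC(=O)COc1cccc2ccccc12)C(=O)N[C@@H](CC(=O)O)C(=O)COc1ccccc1[N+](=O)[O-]` reaches only a limit of this assay, > 100000 nM. Compound 3 `CC(C)[C@H](NC(=O)COc1cccc2ccccc12)C(=O)N[C@@H](CC(=O)O)C(=O)COc1ccc(F)cc1F` gives 33200 nM, the lowest of the two numbers shown, with a 2.6-fold lower number from compound 1 to compound 3 (0.42 log units; beyond the scatter) and an at least 3.0-fold lower number from compound 2 to compound 3 (0.47 log units; beyond the scatter). Compound 4 `CC(C)[C@H](NC(=O)COc1cccc2ccccc12)C(=O)N[C@@H](CC(=O)O)C(=O)COc1c(F)cc(F)cc1F` differs from compound 3 by fluoro in place of hydrogen on an aromatic carbon. Among the compounds with values here, no measured step adds a single fluoro to an otherwise unchanged ring; the two steps that exchange the whole aryl group were only modest, so a step no larger than those is expected here, and its direction is not settled by the measured compounds. The expected step is a 1.3-fold lower number from compound 3 to compound 4 (0.12 log units; within the scatter). Compound 4 is therefore estimated at 25000 nM, within a range from 9000 nM to 70000 nM.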

Compound 4, half-maximal inhibitory concentration: 6840 nM
Compound 4: the middle estimate sits 3.7-fold (0.56 log units) above what was measured, and the stated range ends above it.
By their numbers in this assay, from the lowest: compound 4; then compound 3; then compound 1. At a limit, above all of these: compound 2.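

Placing fluoro on the aromatic carbon ortho to a large group gives a 4.9-fold lower number from compound 3 to compound 4 (0.69 log units; beyond the scatter) in this assay, so a single added fluoro at this position has an effect beyond the scatter, which no earlier step could show. The resulting 2,4,6-trifluorophenyl group also gives a 13-fold lower number from compound 1 to compound 4 (1.11 log units; beyond the scatter) and an at least 14-fold lower number from compound 2 to compound 4 (1.16 log units; beyond the scatter). The second of these steps rests on a limit for compound 2, not a number: the limit of > 100000 nM in this assay, at which 1 of the 4 values shown sits.

The compounds shown leave open whether this position needs fluoro specifically or would respond the same way to chloro, methyl or methoxy. They also leave open how a ring carrying fluoro at this position alone would compare.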